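A few compounds are considered here, and "the series" means these few. Any claim that something is new, unique, unknown or untested is made for them only; others in the source may bear on it.

Among the compounds with values here, in a functional assay on MCF7 cells (Homo sapiens) for antiproliferative activity, read by MTT assay, with a stated time of 48 h (a higher number here means a weaker inhibitor, a lower number a stronger inhibitor), compound 2 `O=C(CN1CCCC1)Nc1ccc2ncnc(Nc3ccc(Cl)cc3)c2c1` gives 16000 nM, the only exact number so far. Compound 1 `O=C(CN1CCCC1)Nc1ccc2ncnc(Nc3cccc(C(F)(F)F)c3)c2c1` gives > 100000 nM, which is a limit of the assay and not a number. Within the data shown here, the single measured step is an at least 6.2-fold lower number from compound 1 to compound 2 (0.79 log units; beyond the scatter), and it swaps 3-(trifluoromethyl)phenyl for 4-chlorophenyl on the nitrogen. Compound 3 `O=C(CN1CCCC1)Nc1ccc2ncnc(Nc3cccc(Br)c3)c2c1` differs from compound 2 at that same place, with 3-bromophenyl in place of 4-chlorophenyl on a nitrogen on an aromatic ring. Among the measured compounds shown here, its group is numbered like that of compound 1, so the step of an at least 6.2-fold lower number from compound 1 to compound 2 (0.79 log units; beyond the scatter) is the only guide, read backwards. It is a rough guide, since bromine is not trifluoromethyl, and a smaller move than that one seems likely. The expected change is a 2.5-fold higher number from compound 2 to compound 3 (0.40 log units; beyond the scatter), a modest rise in the number. Compound 3 is estimated at 40000 nM, with an expected range of 12000 nM to 100000 nM.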

Compound 3, half-maximal inhibitory concentration: 12000 nM
For compound 3 the middle estimate is 3.3-fold (0.52 log units) above the measured one; the range from low to high includes it.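

In this assay, a 1.3-fold lower number from compound 2 to compound 3 (0.12 log units; within the scatter), so 3-bromophenyl and 4-chlorophenyl on this nitrogen cannot be told apart, even though both the halogen and its numbered ring position differ. With the ring numbering kept the same, the change of bromo in place of trifluoromethyl gives an at least 8.3-fold lower number from compound 1 to compound 3 (0.92 log units; beyond the scatter), so among these three compounds the poor result goes with the trifluoromethyl group and not with the numbering alone. Compound 1 stands at a limit of the assay and not at a number: the limit of > 100000 nM in this assay, at which 1 of the 3 values shown sits.

Going by these compounds, whether a halogen is needed at all remains open, and a plain phenyl or a phenyl carrying an amine or a carboxylic acid at this place would test it. A 4-bromophenyl group would also show whether bromo and chloro stay level at the same ring position.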